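A few compounds are considered here, and "the series" means these few. Any claim that something is new, unique, unknown or untested is made for them only; others in the source may bear on it.

Working notes on the series around the shared core of compound 1 `CCN1CCCC1CNC(=O)c1cc(N(C)S(C)(=O)=O)c(C)cc1OC`. In a functional assay on the whole organism for inhibition, with Mus musculus as the target (a lower number here means that less compound is needed, a higher number that more compound is needed for the effect), compound 1 gives 26.1 mg/kg. Compound 2 `CCN1CCCC1CNC(=O)c1cc(NS(N)(=O)=O)ccc1OC` differs from compound 1 in two places at once. In this assay compound 2 returns only a limit, > 50 mg/kg, so it stands at the limit of > 50 mg/kg in this assay, at which 1 of the 2 values shown sits, and no number is known for it. Compound 3 `CCN1CCCC1CNC(=O)c1cc(NS(N)(=O)=O)c(C)cc1OC` is compound 2 with methyl in place of hydrogen on an aromatic carbon. Within the data shown here, no measured step covers this single change; the shift is expected to be small and toward less compound needed, as in an at least 1.2-fold lower number from compound 2 to compound 3 (0.09 log units; that floor lies within the scatter). Compound 3 is estimated at 40 mg/kg, within 15 mg/kg to 150 mg/kg.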

Compound 3, dose for half-maximal effect: > 50 mg/kg
Compound 3: only a limit was reported (the forecaster's own chance of this, stated with the estimate: 45%); middle value at least 1.2-fold (0.09 log units) from the limit.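

In this assay compound 3 gives only a limit, so, like compound 2, it has no number, and the step for methyl in place of hydrogen cannot be read. Among these compounds, the one readable step at this stage concerns the other position, sulfamoylamino in place of methyl(methylsulfonyl)amino, and shows an at least 1.9-fold higher number from compound 1 to compound 3 (0.28 log units; that floor lies within the scatter). Only compound 1 now carries a number in the series: the limit of > 50 mg/kg in this assay, at which 2 of the 3 values shown sit.

As far as these compounds go, whether methyl on this aromatic carbon changes the dose needed at all remains open. Also open, from the compounds shown here alone, is how an ethyl group or a chlorine atom would read there, or a methylsulfonylamino group in place of sulfamoylamino.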